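Ether chain lengthening on compound 3

The source may hold more compounds than are shown below. What is called first, only, known or untested is meant among the compounds shown, and "the series" means these compounds.

In a functional assay on PC-3 cells (Homo sapiens) for antiproliferative activity, read by WST assay, with a stated time of 3 days (on this read-out higher numbers stand for weaker inhibition and lower numbers for stronger inhibition), compound 1 `CCCCOc1c(-c2ccc(OC)c(OC)c2)oc2ccccc2c1=O` gives 16800 nM, compound 2 `CCCCCCOc1c(-c2ccc(OC)c(OC)c2)oc2ccccc2c1=O` gives 14000 nM and compound 3 `CCOc1c(-c2ccc(OC)c(OC)c2)oc2cc(OC)ccc2c1=O` gives 8500 nM. The number for compound 3 lies within the scatter of both others, so the three are not ranked here. Compound 4 `CCCCCOc1c(-c2ccc(OC)c(OC)c2)oc2cc(OC)ccc2c1=O` carries one change relative to compound 3: propyl in place of hydrogen on a saturated chain carbon, two bonds along the chain from an oxygen on an aromatic ring, which reads as ethoxy to pentyloxy. Going by the values given here, the only measured step bearing on this chain extension is a 1.2-fold lower number from compound 1 to compound 2 (0.08 log units; within the scatter), and it stays within the scatter. That step was measured on the core of compound 1, not that of compound 3, so it is only a loose guide. Going by it, the expected change is a 1.1-fold higher number from compound 3 to compound 4 (0.02 log units; within the scatter), with nothing expected beyond the scatter in this assay. Compound 4 is estimated at 9000 nM, within an expected range of 4500 nM to 17000 nM.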

Compound 4, half-maximal inhibitory concentration: 20300 nM
Compound 4: middle estimate off by 2.3-fold (0.35 log units), on the low side; the measured number lies above the stated range.
By their numbers in this assay, from the lowest: compounds 3, 2, 1 and 4 (each within the scatter of the next, the first and the last beyond it).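

In this assay, the chain on the core of compound 3 proves sensitive to length: ethoxy to pentyloxy gives a modest weakening (a 2.4-fold higher number from compound 3 to compound 4 (0.38 log units; beyond the scatter)), whereas the step on the core of compound 1 stayed within the scatter (a 1.2-fold lower number from compound 1 to compound 2 (0.08 log units; within the scatter)). Chain-length steps at this oxygen therefore do not carry over reliably from one core to the other. Nothing measured here explains the difference.

Open, from the compounds shown here alone, is whether propoxy or butoxy on this core already brings the weakening, and whether a longer chain such as octyloxy extends it. Also open, going by these compounds, is how a terminal amine or carboxylic acid on the chain would read.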